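A few compounds are considered here, and "the series" means these few. Any claim that something is new, unique, unknown or untested is made for them only; others in the source may bear on it.

Measured so far:
compound 1, `CNc1nc(NCCCN(C)C)c2oc(-c3ccccc3)cc2n1`: 214 ug/mL
compound 2, `CNc1nc(NCCCN(C)C)c2sc(-c3ccc(NS(C)(=O)=O)cc3)cc2n1`: > 100 ug/mL

In a physicochemical assay for solubility, at pH 2 (on this read-out higher numbers stand for higher solubility and lower numbers for lower solubility), compound 1 gives 214 ug/mL. For compound 2 the figure of > 100 ug/mL in this assay is a limit of the assay and not a number. From the compounds shown here alone, compound 2 therefore stands at the limit of > 100 ug/mL in this assay, at which 1 of the 2 values shown sits, and how far beyond that line it lies is unknown. Compound 3, `CNc1nc(NCCCN(C)C)c2sc(-c3ccccc3)cc2n1`, has not yet been measured in this assay. It differs from compound 2 in one place: hydrogen in place of methanesulfonamido on an aromatic carbon. Within the data shown here, no measured pair shows this change, so its size cannot be read from the numbers; compound 1, which also lacks the methanesulfonamido group, gives 214 ug/mL in this assay. Compound 3 is expected to fall modestly, the step of an at least 1.1-fold lower number from compound 2 to compound 3 (0.04 log units; that floor lies within the scatter) being small relative to the scatter. The estimate for compound 3 in this assay is 90 ug/mL, within 30 ug/mL to 300 ug/mL.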

Compound 3, solubility: > 100 ug/mL
Compound 3 was reported as a limit; the forecaster's own chance of this, stated with the estimate: 40%; middle value at least 1.1-fold (0.04 log units) away from the limit.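

In this assay, among these compounds, compound 2 and compound 3 are both reported only as limits of the assay, so no step between them can be read: the limit of > 100 ug/mL in this assay, at which 2 of the 3 values shown sit.

From the compounds shown here alone, how far either compound lies beyond that limit, and what replacing methanesulfonamido with hydrogen changes in this read-out, stays open.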